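Swapping a Para Substituent on a Weak Cytotoxic Thiazole Hydrazone

The source may hold more compounds than are shown below. What is called first, only, known or untested is meant among the compounds shown, and "the series" means these compounds.

Three compounds share one core and differ only in the small ring attached through a sulfur-linked acetyl hydrazide. Compound 1 `COc1ccc(-c2cs/c(=N/NC(=O)CSc3nncn3C)n2-c2ccccc2)cc1` and compound 3 `COc1ccc(-c2cs/c(=N/NC(=O)CSc3nnnn3C)n2-c2ccccc2)cc1` carry two different small heteroaromatic rings at that end; in a functional assay on C6 cells (Rattus norvegicus) for cytotoxicity, read by MTT assay, with a stated time of 24 h (a higher number here means a weaker inhibitor, a lower number a stronger inhibitor), compound 1 is recorded as "not determined" (no result reported), and in this assay compound 3 is recorded as "not determined" (no result reported). For the measured compounds named here, compound 2 `COc1ccc(-c2cs/c(=N/NC(=O)CSc3ncccn3)n2-c2ccccc2)cc1`, which carries a pyrimidine at the same end, is the only member with a number: in this assay compound 2 gives 102 ug/mL. Compound 2 thus stands alone on the scale, with the two other entries offering nothing to compare against, and the value itself marks it as a weak inhibitor of the growth of these cells.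

Compound 4 `O=C(CSc1ncccn1)N/N=c1/scc(-c2ccc(Cl)cc2)n1-c1ccccc1` keeps the pyrimidine end of compound 2 and changes the other aromatic ring: chloro in place of methoxy on an aromatic carbon. No comparison between measured compounds is available for this kind of exchange, so there is no shown step to lean on. The expected step from compound 2 to compound 4 in this assay is small, a 1.1-fold lower number from compound 2 to compound 4 (0.05 log units; within the scatter), not clearly beyond the usual scatter in either direction. Compound 4 is therefore estimated to give about 90 ug/mL in this assay, with a likely range from 40 ug/mL to 200 ug/mL.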

Compound 4, half-maximal inhibitory concentration: 83.3 ug/mL
Beside the measured number, compound 4's estimate is 1.1-fold (0.03 log units) above it; the measured number falls inside the stated range.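

In this assay, for the compounds shown here, replacing methoxy with chloro on the aromatic ring gives a 1.2-fold lower number from compound 2 to compound 4 (0.09 log units; within the scatter) and this is the first reading of any change at this position, where compound 2 alone could show only a single number. With the pyrimidine end held constant, the change from 4-methoxyphenyl to 4-chlorophenyl leaves the two compounds indistinguishable on this scale, so this exchange provides no evidence that the position controls the cytotoxic reading. Nothing available explains this result or connects it to a measured property of either group.

The compounds shown leave open whether a quite different group at the same place, such as an amine, a carboxylic acid or a longer alkyl chain, would produce a step beyond the usual scatter. They also leave open whether the exchange of methoxy for chloro would give a similarly small step with another ring at the far end, such as the small heteroaromatic rings of compound 1 and compound 3.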